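The source may report more compounds than this note shows. Statements on the series, on what has been measured and on what is new or still open speak of the compounds shown alone.

Values in a functional assay on A10 cells (Rattus norvegicus) for activation, read by immunofluorescence, with a stated time of 18 h; on this read-out lower numbers stand for an effect already at smaller amounts and higher numbers for an effect only at larger amounts of compound:
- compound 1 `Cc1coc2ncnc(N(C)c3ccc(N(C)C)cc3)c12`: 140 nM
- compound 2 `Cc1coc2ncnc(Nc3ccc([N+](=O)[O-])cc3)c12`: > 10000 nM (a limit)
- compound 3 `CNc1ccc(Nc2ncnc3occ(C)c23)cc1`: > 10000 nM (a limit)

Compound 3 has no number, only a limit, and stands at the limit of > 10000 nM in this assay, at which 2 of the 3 values shown sit. For the measured compounds named here, compound 2 shares that limit, so compound 1 is the only compound with a number.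

Next in the series is compound 4 `Cc1coc2ncnc(Nc3ccc(N(C)C)cc3)c12`, not yet measured. The change is methyl in place of hydrogen on a nitrogen on an aromatic ring, which turns methylamino into dimethylamino.

Going by the values given here, the only measured step is a step that the two limits leave unreadable from compound 2 to compound 3. It offers no size to carry over to this change. Compound 1 gives 140 nM, which shows that a compound with the shared core can reach a measurable value in this assay. Among the compounds with values here, no measured step connects compound 1 to this change, so that value sets no expected size.

Any shift in this assay is expected to run toward lower numbers, but only modestly, and the starting point is itself a limit. The expected change is an at least 2.0-fold lower number from compound 3 to compound 4 (0.30 log units; that floor lies within the scatter), an estimate with little support from measured steps. For compound 4 the estimated value is 5000 nM, with an expected range from 800 nM to 15000 nM. A report of only a limit remains a likely outcome.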

Compound 4, half-maximal effective concentration: > 10000 nM
Compound 4 gave a limit, no number; the forecaster's own chance of this, stated with the estimate: 55%; at least 2.0-fold (0.30 log units) between middle value and limit.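

With dimethylamino in place of methylamino, compound 4 still gives only a limit in this assay, and the steps linking compound 2, compound 3 and compound 4 cannot be read, so this change shows no measurable gain on that nitrogen. For the compounds shown here, compound 4 does provide the first readable step, an at least 71-fold higher number from compound 1 to compound 4 (1.85 log units; beyond the scatter), with hydrogen in place of methyl on a nitrogen on an aromatic ring; between these two compounds, that single difference separates the only number from a limit. Compound 1 is therefore the only compound shown that gives a number, while the other three share one limit: the limit of > 10000 nM in this assay, at which 3 of the 4 values shown sit.

Still open, on these data alone, is whether methyl on that same nitrogen would also give a number when methylamino or nitro replaces dimethylamino on the aromatic carbon, and how far the compounds at the limit differ from one another. Also open, as far as these compounds go, is how this assay would read with ethyl or a longer chain in place of that methyl, or with a carboxylic acid in place of dimethylamino.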